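This account rests on a few compounds, and the source may have more. Where it says the series, first, only, none or still open, it means among the compounds named here.

Measured so far:
- compound 1, `CC(C)(C)OC(=O)N1CCC(CCCNc2ccc3c(c2)OCCS3(=O)=O)CC1` — "not determined" (no result reported)
- compound 2, `CC(C)(C)OC(=O)N1CCC(CCCNc2ccc3c(c2)OCC3=O)CC1` — 108%
- compound 3, `CC(C)(C)OC(=O)N1CCC(CCCNc2ccc3c(c2)CNC3=O)CC1` — 102%

Two compounds of this set carry a number in a functional assay on CHO-K1 cells for agonist activity at Glucose-dependent insulinotropic receptor (Mus musculus), read by HTRF and cAMP accumulation, with a stated time of 30 min; on this read-out higher numbers stand for larger maximal responses and lower numbers for smaller maximal responses. Compound 2 gives 108% there, and compound 3 gives 102%; the gap between them lies within the usual scatter, so the two cannot be told apart on this read-out. Compound 1 has no number, so it gives no anchor.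

The step from compound 2 to compound 4, `CC(C)c1nsc(N2CCC(CCCNc3ccc4c(c3)OCC4=O)CC2)n1`, changes one group: 3-isopropyl-1,2,4-thiadiazol-5-yl in place of tert-butoxycarbonyl on an amine nitrogen in a ring. For the measured compounds named here, no pair of measured compounds shows what such an exchange on this nitrogen does to the maximal response, so the expectation rests on the two numbers alone, both of which lie close to a full response. A small step in either direction, or none beyond the scatter, is the expected outcome for a number 8 percentage points lower from compound 2 to compound 4 (within the scatter). Compound 4 is therefore estimated to reach 100% in this assay, expected to fall between 80% and 115%.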

Compound 4, largest response reached (Emax), in percent of the reference or control that the assay uses: 93%
The estimate for compound 4 lay 7 percentage points above the measured number; the range from low to high includes it.
By their numbers in this assay, from the lowest: compounds 4, 3 and 2 (each within the scatter of the next, the first and the last beyond it).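

For the compounds shown here, the first exchange at this position, 3-isopropyl-1,2,4-thiadiazol-5-yl in place of tert-butoxycarbonyl on the amine nitrogen in the ring, gives a number 15 percentage points lower from compound 2 to compound 4 (beyond the scatter) in this assay and is a modest but real loss. The tert-butoxycarbonyl group is still not needed for a sizeable response, since compound 4 reaches 93% with a five-membered aromatic ring on this nitrogen. Nothing measured here explains the size of this step.

A single exchange cannot show whether other groups on this nitrogen, such as a pyrimidin-2-yl ring or a plain acetyl group, would keep the response at the level of compound 2. It also leaves open whether the same exchange would act alike on the core of compound 3.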